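Aryl variation at the enaminone nitrogen, cytotoxicity series

A few compounds are considered here, and "the series" means these few. Any claim that something is new, unique, unknown or untested is made for them only; others in the source may bear on it.

Measured compounds:
compound 1 `O=C(/C=C\Nc1ccc(F)cc1)c1nc(-c2ccc(F)cc2)n2ccccc12`, 16900 nM
compound 2 `O=C(/C=C\Nc1cnc2ccccc2c1)c1nc(-c2ccccc2)n2ccccc12`, 19700 nM
compound 3 `O=C(/C=C\Nc1ccc(F)cc1)c1nc(-c2ccc(C(F)(F)F)cc2)n2ccccc12`, > 30000 nM

In a functional assay on BT-474 cells (Homo sapiens) for cytotoxicity, read by MTT assay, with a stated time of 48 h (on this read-out lower numbers stand for stronger inhibition and higher numbers for weaker inhibition), compound 2 gives 19700 nM, the higher of the two plain numbers; compound 1 gives 16900 nM, and the gap between them lies within the scatter. For compound 3 the assay reports only a limit, > 30000 nM (the limit of > 30000 nM in this assay, at which 1 of the 3 values shown sits). Among the measured compounds shown here, the single step between measured compounds, an at least 1.7-fold higher number from compound 1 to compound 3 (0.24 log units; that floor lies within the scatter), changes a group on an aromatic carbon of the shared core, not the group on the amine nitrogen, so it does not bear on the step taken here.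

Compound 4 `COc1ccc(N/C=C\C(=O)c2nc(-c3ccccc3)n3ccccc23)cc1` is not yet measured. It differs from compound 2 in one place: 4-methoxyphenyl in place of quinolin-3-yl on an amine nitrogen. For the measured compounds named here, no measured pair probes this position, so no direction is supported. Compound 1 and compound 2 carry different groups on that nitrogen and sit within the scatter of each other, which gives no sign of a shift. For compound 4 the expected step is a 1.0-fold lower number from compound 2 to compound 4 (0.02 log units; within the scatter), none beyond the scatter. Compound 4 is estimated at 19000 nM, from 8000 nM to 40000 nM.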

Compound 4, half-maximal inhibitory concentration: 12800 nM
The estimate for compound 4 lay 1.5-fold (0.17 log units) above the measured number; the measured number falls inside the stated range.
By their numbers in this assay, from the lowest: compounds 4, 1 and 2 (each within the scatter of the next). At a limit, above all of these: compound 3.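

In this assay, this is the only pair shown that changes the group on the amine nitrogen while the rest of the structure stays fixed: a 1.5-fold lower number from compound 2 to compound 4 (0.19 log units; within the scatter). Exchanging quinolin-3-yl, with its two six-membered aromatic rings, for 4-methoxyphenyl, with one, therefore produces no shift that can be told from the scatter, so the second ring of quinolin-3-yl is not required for a value in this range in this pair. No measured property shown here bears on this step.

From the compounds shown here alone, whether any group on this nitrogen can move the number beyond the scatter remains open, as a single pair of two aryl groups cannot define a trend. The compounds shown also leave open how a non-aromatic group such as cyclohexyl or benzyl, or an aryl group carrying a carboxylic acid or a dimethylamino group, would read out at this position.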